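A smaller group replaces a five-membered ring

A few compounds are considered here, and "the series" means these few. Any claim that something is new, unique, unknown or untested is made for them only; others in the source may bear on it.

In a functional assay on K562 cells (Homo sapiens) for antiproliferative activity, read by MTT assay, with a stated time of 48 h (on this read-out higher numbers stand for weaker inhibition and lower numbers for stronger inhibition), compound 1 (`COc1cc(CNC(=O)CCCCCCC(C)C)ccc1OC(=O)CCC(=O)Oc1ccc(-c2cc(=S)ss2)cc1`) gives 5930 nM and compound 2 (`COc1cc(CNC(=O)CCCC/C=C/C(C)C)ccc1OC(=O)CCC(=O)Oc1ccc(-c2cc(=S)ss2)cc1`) gives 4450 nM as its reading. For the measured compounds named here, the one measured step, a 1.3-fold lower number from compound 1 to compound 2 (0.12 log units; within the scatter), lies within the scatter, so compound 2 cannot be told apart from compound 1 on these numbers.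

Compound 3 (`COc1cc(CNC(=O)CCCC/C=C/C(C)C)ccc1OC(=O)CCC(=O)Oc1ccc(C(N)=S)cc1`) keeps the chain of compound 2 and changes another part of the molecule: a group of 3 heavy atoms (1 carbon, 1 nitrogen, 1 sulfur; no ring) in place of a group of 6 heavy atoms (3 carbon, 3 sulfur; one five-membered aromatic ring with 2 hetero atoms), on an aromatic carbon. The change sits on an aromatic carbon, para to a large group. Going by the values given here, the measured step altered only the chain, so it offers no direct guide to this swap, and no measured compound carries the entering group. A modest move toward weaker inhibition is therefore a cautious expectation, with real uncertainty in both directions. The estimated step is a 1.8-fold higher number from compound 2 to compound 3 (0.25 log units; within the scatter) for this swap. In this assay compound 3 is expected at about 8000 nM (estimated range 2500 nM to 25000 nM).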

Compound 3, half-maximal inhibitory concentration: > 50000 nM
Compound 3 was reported as a limit (the forecaster's own chance of this, stated with the estimate: 10%); middle value at least 6.2-fold (0.79 log units) from the limit.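

In this assay, for the compounds shown here, this aromatic carbon proves far more sensitive than the chain change among the earlier compounds, which stayed within the scatter: replacing the five-membered aromatic ring group with the smaller, ring-free group gives an at least 11-fold higher number from compound 2 to compound 3 (1.05 log units; beyond the scatter). The group at this position therefore has a large bearing on the antiproliferative reading, and keeping the chain of compound 2 does not preserve activity. Compound 3 is reported only as a limit, not as an exact number: the limit of > 50000 nM in this assay, at which 1 of the 3 values shown sits.

With a single replacement group in view, the compounds shown cannot separate the effect of losing the ring from the effect of the particular group that enters. A nitrile, a carboxylic acid or an amine on this aromatic carbon would help show whether any group other than the original ring can hold the reading.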